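The compounds below may be only part of what the source reports. "The series", "measured", "known", "first", "only" and "open" are said of these compounds alone.

Compound 1 `CCOC(=O)c1ccc(-c2nn(Cc3ccccc3Cl)c3ccccc23)cc1` — in a functional assay on cells (Platelet, Homo sapiens) for inhibition (a higher number here means a weaker inhibitor, a lower number a stronger inhibitor), compound 1 gives > 10000 nM, a limit of the assay rather than a number.
Compound 2 `CCOC(=O)c1ccc(-c2nn(Cc3ccccc3F)c3ccccc23)cc1` — compound 2 gives > 10000 nM, again a limit.
Compound 3 `CCOC(=O)c1ccc(-c2nn(Cc3cccc(F)c3)c3ccccc23)cc1` — compound 3 gives > 10000 nM, also a limit.

Compound 3 therefore stands at the edge of what this assay can report, and it shares that position with the other two: the limit of > 10000 nM in this assay, at which 3 of the 3 values shown sit. None of the three steps among the measured compounds can be read, since a step that the two limits leave unreadable from compound 1 to compound 2, a step that the two limits leave unreadable from compound 1 to compound 3 and a step that the two limits leave unreadable from compound 2 to compound 3 all run between limits.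

Compound 4 `CCOC(=O)c1ccc(-c2nn(Cc3cccc(OC)c3)c3ccccc23)cc1` differs from compound 3 in one place: methoxy in place of fluoro on an aromatic carbon. Among the compounds with values here, no measured step bears on this change in a readable way, because the halogen swaps and the shift of a fluoro from one position of the benzyl ring to another left every value at the limit. Within the data shown here, the only guidance is that all three measured members sit at the limit, so the estimate for compound 4 leans toward a weak inhibitor as well. Compound 4 is expected to show 15000 nM, within a range from 3000 nM to 60000 nM. The step this estimate implies, a step that the limit leaves unreadable from compound 3 to compound 4, is expected to be none beyond the scatter.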

Compound 4, half-maximal inhibitory concentration: > 10000 nM
Compound 4 gave a limit, no number (the forecaster's own chance of this, stated with the estimate: 70%); the middle value lies beyond the limit too.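

No new step can be read between compound 4 and compound 1, compound 2 or compound 3, because each of these values is a limit and not a number: the limit of > 10000 nM in this assay, at which 4 of the 4 values shown sit.

The compounds shown leave open how far these four differ from one another in this assay, and whether any substituent on the benzyl group gives a measurable value.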